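Removing one methyl from the saturated ring of compound 2

The source may report more compounds than this note shows. Statements on the series, on what has been measured and on what is new or still open speak of the compounds shown alone.

Compound 2 `CC1(C)CC(=O)c2s/c(=N/c3ccc(Cl)cc3)oc2C1` gives 4260 nM in a functional assay on PC-3 cells (Homo sapiens) for antiproliferative activity, read by sulforhodamine B assay (a higher number here means a weaker inhibitor of growth, a lower number a stronger inhibitor of growth), and compound 1 `CC1CC(=O)c2s/c(=N/c3ccccc3)oc2C1` gives 2630 nM in this assay; the two numbers lie within the usual scatter of one another. Compound 3 `CC1CC(=O)c2s/c(=N/c3ccc(Cl)cc3)oc2C1` differs from compound 2 by hydrogen in place of methyl on a saturated ring carbon. For the measured compounds named here, no measured pair shows this change, so no step beyond the scatter is expected in either direction. On that basis compound 3 is estimated at 3200 nM, with a range of 1200 nM to 8500 nM, which would mean an expected step of a 1.3-fold lower number from compound 2 to compound 3 (0.12 log units; within the scatter).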

Compound 3, concentration for 50% growth inhibition: 16500 nM
For compound 3 the middle estimate is 5.2-fold (0.71 log units) below the measured one, outside the stated range (above it).
By their numbers in this assay, from the lowest: compounds 1 and 2 (each within the scatter of the next); then compound 3.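

In this assay, hydrogen in place of methyl on a saturated ring carbon gives a 3.9-fold higher number from compound 2 to compound 3 (0.59 log units; beyond the scatter) as a step beyond the scatter, so this position does not tolerate the change silently. Chloro in place of hydrogen on an aromatic carbon gives a 6.3-fold higher number from compound 1 to compound 3 (0.80 log units; beyond the scatter) when only one methyl stands on the saturated ring, so the chloro group weakens growth inhibition in that setting. Nothing shown gives a reason for either step. The compounds shown leave open how an ethyl group or a hydroxyl group on that saturated ring carbon would read, and whether bromo or methoxy in place of chloro would follow the same course.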